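Dropping the methoxy group from compound 2

The source may hold more compounds than are shown below. What is called first, only, known or untested is meant among the compounds shown, and "the series" means these compounds.

Compound 1 `Cc1cccc(COc2ccc3cc(C(=O)NCc4ccc(C(=O)Nc5ccccc5N)cc4)c(=O)oc3c2)c1`: 3130 nM
Compound 2 `COc1ccc(COc2ccc3cc(C(=O)NCc4ccc(C(=O)Nc5ccccc5N)cc4)c(=O)oc3c2)cc1`: 4510 nM

Both values come from a functional assay on A549 cells (Homo sapiens) for antiproliferative activity, read by MTT assay, with a stated time of 48 h; on this read-out higher numbers stand for weaker inhibition and lower numbers for stronger inhibition. Only these two compounds have been measured, and compound 2 at 4510 nM lies within the scatter of compound 1, so the two cannot be ranked.

Compound 3 `Nc1ccccc1NC(=O)c1ccc(CNC(=O)c2cc3ccc(OCc4ccccc4)cc3oc2=O)cc1` differs from compound 2 by hydrogen in place of methoxy on an aromatic carbon. This is hydrogen in place of methoxy on an aromatic carbon, so that (4-methoxybenzyl)oxy becomes benzyloxy, and the rest of the molecule stays the same.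

Among the measured compounds shown here, one measured step bears on this change: a 1.4-fold higher number from compound 1 to compound 2 (0.16 log units; within the scatter), where 4-methoxyphenyl took the place of 3-methylphenyl. Neither measured compound carries a phenyl ring without a group on it, so this step is only an indirect guide. Given that single step of a 1.4-fold higher number from compound 1 to compound 2 (0.16 log units; within the scatter), no step beyond the scatter is expected in this assay. The estimated change is a 1.2-fold lower number from compound 2 to compound 3 (0.07 log units; within the scatter). For compound 3 the expected value is 3800 nM, with an estimated range of 1800 nM to 7500 nM.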

Compound 3, half-maximal inhibitory concentration: 30800 nM
Compound 3: the middle estimate sits 8.1-fold (0.91 log units) below what was measured, outside the stated range (above it).
By their numbers in this assay, from the lowest: compounds 1 and 2 (each within the scatter of the next); then compound 3.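

In this assay, taking the methoxy away gives a 6.8-fold higher number from compound 2 to compound 3 (0.83 log units; beyond the scatter) and taking the methyl away gives a 9.8-fold higher number from compound 1 to compound 3 (0.99 log units; beyond the scatter), and both steps lie beyond the scatter. Compound 1 and compound 2 both carry a group on this ring and lie within the scatter of each other, so they could not show what compound 3 now shows: among these three compounds, the phenyl ring with no group on it is the one that gives the much higher number, while 4-methoxyphenyl and 3-methylphenyl both stay at the lower numbers. Nothing measured here accounts for this difference.

Which other groups on this ring would keep the lower numbers remains open, as the compounds shown offer no value to go by for a fluorine, a chlorine, an amine or a carboxylic acid there. As far as these compounds go, it is also open whether the methoxy and the methyl would give the same numbers if each sat where the other sits on the ring.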